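The compounds below may be only part of what the source reports. "The series", "measured", "known", "first", "only" and "open" are said of these compounds alone.

Measured so far:
- compound 1, `Nc1scc(CN2CCN(c3ccc(Cl)cc3F)CC2)c1C(=O)c1ccc(Cl)cc1`, gives 1% in an assay on CHO cells for displacement of a labelled ligand from adenosine receptor A3 (Homo sapiens), read by scintillation counting, with a stated time of 120 min, tested at 10 uM; on this read-out higher numbers stand for more inhibition at the one concentration tested (going by the name of the read-out) and lower numbers for less inhibition.
- compound 2, `Nc1scc(CN2CCN(c3ccc(C(F)(F)F)cc3)CC2)c1C(=O)c1cccc(C(F)(F)F)c1`, gives 0% in this assay.

Compound 1 and compound 2 share a core and differ in the aromatic groups at two places. In this assay compound 1 gives 1% and compound 2 gives 0%. These two numbers lie within the usual scatter of each other, so neither compound can be said to inhibit more than the other: both show essentially no displacement of the labelled ligand at the concentration tested.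

Compound 3, `Nc1scc(CN2CCN(C3CCCCCC3)CC2)c1C(=O)c1ccc(Cl)cc1`, has not yet been measured. It keeps the core of compound 1 and differs from it in one place: cycloheptyl in place of 4-chloro-2-fluorophenyl on an amine nitrogen in a ring. For the measured compounds named here, no step between two measured compounds is available to show what such an exchange does here, so the expectation rests only on the two measured numbers, both near the bottom of the scale.

Given that compound 1 gives 1%, the step of a number 2 percentage points higher from compound 1 to compound 3 (within the scatter) is expected to be none beyond the scatter. For compound 3 in this assay the estimated value is 3%, with a range from -8% to 15%.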

Compound 3, a percentage reported as inhibition, at one concentration (the size of the read-out at that concentration, not a potency): 0%
The estimate for compound 3 lay 3 percentage points above the measured number; measured number inside the range.
By their numbers in this assay, from the lowest: compounds 2, 3 and 1 (each within the scatter of the next).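

For the compounds shown here, this is the first exchange made in one place only: on an amine nitrogen in a ring, cycloheptyl in place of 4-chloro-2-fluorophenyl gives, in this assay, a number 1 percentage points lower from compound 1 to compound 3 (within the scatter). It shows that a seven-membered non-aromatic ring of carbon only and a six-membered aromatic ring carrying chlorine and fluorine cannot be told apart at this position, with both compounds near the bottom of the scale at the one concentration tested. No measurement shown here offers an explanation for this reading.

From the compounds shown here alone, whether an amine, a carboxylic acid or a longer chain in this place would give a number clear of the scatter remains open. Also open, going by these compounds, is whether cycloheptyl and 4-chloro-2-fluorophenyl would still read alike on a compound with a clearly higher number, as a step read this close to the bottom of the scale says little about such a case.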